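The compounds below may be only part of what the source reports. "The series", "measured", "known", "first", "only" and "open" are said of these compounds alone.

Compound 1 `CS(=O)(=O)c1ccc(-c2cnc3[nH]cc(-c4nnc(-c5ccc(F)cc5)o4)c(=O)c3c2)cc1` was tested in a functional assay on HCT-116 cells (Homo sapiens) for inhibition, read by MTT assay, with a stated time of 24 h, tested at 2.5 uM (on this read-out higher numbers stand for more inhibition of growth at the one concentration tested and lower numbers for less inhibition of growth), and gives 10.7%. For the measured compounds named here, its only measured neighbour, compound 2 `CS(=O)(=O)c1ccc(-c2cnc3[nH]cc(-c4nnc(-c5ccccn5)o4)c(=O)c3c2)cc1`, gives 5.37% in this assay; the step of a number 5.3 percentage points lower from compound 1 to compound 2 (within the scatter) does not separate the two, so compound 1 stands with compound 2 inside one band of scatter. Compound 3 `Cc1ccc(-c2nnc(-c3c[nH]c4ncc(-c5ccc(S(C)(=O)=O)cc5)cc4c3=O)o2)cc1` is unmeasured and differs from compound 1 by methyl in place of fluoro on an aromatic carbon. Going by the values given here, no measured step covers this exchange; the one step on record replaced the whole aryl group and stayed within the scatter, so no step beyond the scatter is expected here either, a number 0.7 percentage points lower from compound 1 to compound 3 (within the scatter). Compound 3 is estimated at 10%, between 0% and 22%.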

Compound 3, percent growth inhibition at one concentration: 7.47%
Compound 3: the middle estimate sits 2.5 percentage points above what was measured, and the stated range covers the measured number.
By their numbers in this assay, from the lowest: compounds 2, 3 and 1 (each within the scatter of the next).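

In this assay the smallest change so far, methyl in place of fluoro on the six-membered aromatic ring, gives a number 3.2 percentage points lower from compound 1 to compound 3 (within the scatter) and so does not separate the two compounds. The exchange of pyridin-2-yl for 4-methylphenyl gives a number 2.1 percentage points higher from compound 2 to compound 3 (within the scatter) as well, which places all three aryl groups shown at this position inside one band of scatter. No evidence at hand bears on this result.

Going by these compounds, what remains open is whether an amine, a carboxylic acid or a longer chain on this ring would give a step beyond the scatter.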